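Working notes: from compound 1 to compound 3

This account rests on a few compounds, and the source may have more. Where it says the series, first, only, none or still open, it means among the compounds named here.

Among the measured compounds shown here, compound 1 `Cn1ncc2c(-c3ccc(F)cc3)cc(NNC(=O)Nc3cc(Cl)cc(Cl)c3)nc21` is the only member of this small set with an actual number so far: in a functional assay on SW620/5-FU cells (Homo sapiens) for cytotoxicity, read by MTT assay, with a stated time of 48 h, in the presence of a further agent that is not named here (on this read-out lower numbers stand for an effect already at smaller amounts and higher numbers for an effect only at larger amounts of compound), compound 1 gives 54300 nM. Compound 2 `Cc1nn(C)c2nc(NNC(=O)Nc3cc(Cl)nc(Cl)c3)cc(-c3ccco3)c12` reads > 100000 nM, which is a limit of the assay and not a number. For the measured compounds named here, this leaves a single numerical reference point and no measured step from which to size a structural change.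

Compound 3 `Cn1ncc2c(-c3ccc(F)cc3)cc(NNC(=O)Nc3cc(Cl)nc(Cl)c3)nc21` keeps the core of compound 1 and differs in one place, on an amide-type nitrogen: 2,6-dichloropyridin-4-yl in place of 3,5-dichlorophenyl on an amide-type nitrogen. The heavy-atom count of the group stays the same, and the new ring carries one hetero atom.

Going by the values given here, with no measured step to draw on, the working expectation in this assay is no change beyond the usual scatter, with neither direction favoured. The expected move is a 1.1-fold higher number from compound 1 to compound 3 (0.04 log units; within the scatter). A reading for compound 3 at the limit of > 100000 nM in this assay, at which 1 of the 2 values shown sits, remains a real possibility. For compound 3 the estimated value is 60000 nM, with an expected range from 25000 nM to 100000 nM.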

Compound 3, half-maximal effective concentration: 9150 nM
Compound 3: middle estimate off by 6.6-fold (0.82 log units), on the high side; measured number outside the range, below it.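

In this assay, among the compounds shown here, this position gives the first measured step, a 5.9-fold lower number from compound 1 to compound 3 (0.77 log units; beyond the scatter), so the group on the amide-type nitrogen is a place where the read-out responds to a single change. With the rest of compound 1 unchanged and the heavy-atom count of the group the same, the step goes with the exchange of 3,5-dichlorophenyl for 2,6-dichloropyridin-4-yl, which brings one hetero atom into the ring and one hydrogen-bond acceptor to the group. Compound 2 also carries 2,6-dichloropyridin-4-yl but differs from compound 3 in more than one place, and its reading remains a limit and not a number: the limit of > 100000 nM in this assay, at which 1 of the 3 values shown sits.

Nothing among the data shown accounts for the size or direction of the step. Still open, from the compounds shown here alone, is whether a ring with the two chlorines replaced, such as 2,6-dimethylpyridin-4-yl or 2,6-dimethoxypyridin-4-yl, would hold the number of compound 3 in this assay, and whether the same exchange on the amide-type nitrogen would give a step of similar size on a core carrying a different group from that of compound 1.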